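Replacing 4-fluorophenyl with 3-chlorophenyl in compound 2

The source may hold more compounds than are shown below. What is called first, only, known or untested is meant among the compounds shown, and "the series" means these compounds.

Among the compounds with values here, in an ADME assay on L929 cells (Mus musculus) for cytotoxicity, read by resazurin assay, with a stated time of 96 h (on this read-out lower numbers stand for higher toxicity in this test and higher numbers for lower toxicity in this test), compound 2 `NC(=S)N/N=C(\COc1ccc(F)cc1)c1ccc(Br)cc1` gives 52300 nM, the only true number so far. Compound 1 `CCc1ccc(OC/C(=N\NC(N)=S)c2ccc(Br)cc2)cc1` is reported as < 25500 nM, which is a limit of the assay and not a number.

The next compound, compound 3 `NC(=S)N/N=C(\COc1cccc(Cl)c1)c1ccc(Br)cc1`, differs from compound 2 by 3-chlorophenyl in place of 4-fluorophenyl on an oxygen on a saturated carbon. In words, 3-chlorophenyl stands in place of 4-fluorophenyl on an oxygen on a saturated carbon.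

Within the data shown here, only one measured step bears on this change: an at least 2.0-fold higher number from compound 1 to compound 2 (0.31 log units; beyond the scatter). It rests on (the limit of < 25500 nM in this assay, at which 1 of the 2 values shown sits), and it involves the fluoro group that compound 3 gives up. Among the measured compounds shown here, no measured step shows what a chloro group does, so this is thin guidance. Compound 3 loses the fluoro that accompanied the higher reading in an at least 2.0-fold higher number from compound 1 to compound 2 (0.31 log units; beyond the scatter), so a slight drift toward lower numbers in this assay is expected, but no step beyond the scatter. The expected change is a 1.5-fold lower number from compound 2 to compound 3 (0.16 log units; within the scatter).

For compound 3 the estimated value is 36000 nM, with an expected range from 16000 nM to 80000 nM.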

Compound 3, half-maximal cytotoxic concentration: < 50200 nM
Compound 3 gave a limit, no number (the forecaster's own chance of this, stated with the estimate: 20%); the middle value lies beyond the limit too.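

In this assay compound 3 is reported as < 50200 nM, which is a limit of the assay and not a number. The change of 4-fluorophenyl to 3-chlorophenyl on an oxygen on a saturated carbon can be read only as an at least 1.0-fold lower number from compound 2 to compound 3 (0.01 log units; that floor lies within the scatter), so the true size of this step remains undetermined, and the reading rests on a limit: the limit of < 50200 nM in this assay, at which 1 of the 3 values shown sits. Within the data shown here, what this adds is a second replacement for 4-fluorophenyl at this position that gives a limit, as compound 1 did, which leaves compound 2 as the only compound here with a true number and shows no replacement that has been placed on a measured scale against it.

The change in compound 3 alters both the halogen and where it stands on the ring, and these two changes cannot be separated with the compounds shown. From the compounds shown here alone, it also remains open how the reading would respond to an amine or a carboxylic acid in place of 4-fluorophenyl, or to a longer chain on that oxygen.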